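Cytotoxicity Across Aryl Variants of a Shared Core

A few compounds are considered here, and "the series" means these few. Any claim that something is new, unique, unknown or untested is made for them only; others in the source may bear on it.

Compound 1 `COc1cc(-c2nnc(SCc3ccc(F)cc3F)o2)ccc1O`: 520000 nM
Compound 2 `COc1cc(-c2nnc(SCc3ccccc3Br)o2)ccc1O`: 363000 nM
Compound 3 `COc1cc(-c2nnc(SCc3ccccc3C)o2)ccc1O`: 592000 nM

In an ADME assay on cells (Mus musculus, strain BALB/c) for cytotoxicity, read by MTT assay, with a stated time of 24 h (on this read-out lower numbers stand for higher toxicity in this test and higher numbers for lower toxicity in this test), compound 3 holds the highest of the three numbers shown, but every gap to it sits within the scatter: a 1.1-fold higher number from compound 1 to compound 3 (0.06 log units; within the scatter) and a 1.6-fold higher number from compound 2 to compound 3 (0.21 log units; within the scatter). Compound 4 `COc1cc(-c2nnc(SCc3ccc(Br)cc3)o2)ccc1O` has not yet been measured; it differs from compound 3 as follows: 4-bromophenyl in place of 2-methylphenyl on a saturated chain carbon bound to a sulfur. Going by the values given here, the steps that bear on this change are the aryl swaps, a 1.4-fold lower number from compound 1 to compound 2 (0.16 log units; within the scatter) and a 1.1-fold higher number from compound 1 to compound 3 (0.06 log units; within the scatter), and the exchange of bromo for methyl, a 1.6-fold higher number from compound 2 to compound 3 (0.21 log units; within the scatter), none of them beyond the scatter. Compound 4 is therefore expected to show no step beyond the scatter, a 1.3-fold lower number from compound 3 to compound 4 (0.12 log units; within the scatter). Compound 4 is estimated at 450000 nM, within a range of 250000 nM to 800000 nM.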

Compound 4, half-maximal cytotoxic concentration: 455000 nM
For compound 4 the middle estimate is 1.0-fold (0.00 log units) below the measured one; the measured number falls inside the stated range.
By their numbers in this assay, from the lowest: compounds 2, 4, 1 and 3 (each within the scatter of the next).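

In this assay, the bromo group's new place on the ring makes no difference beyond the scatter, since 4-bromophenyl in place of 2-bromophenyl gives a 1.3-fold higher number from compound 2 to compound 4 (0.10 log units; within the scatter). On a saturated chain carbon bound to a sulfur, 4-bromophenyl also stays within the scatter of 2-methylphenyl, a 1.3-fold lower number from compound 3 to compound 4 (0.11 log units; within the scatter), and of 2,4-difluorophenyl, a 1.1-fold lower number from compound 1 to compound 4 (0.06 log units; within the scatter). No measurement at hand offers an explanation for this flat picture. The compounds shown leave open whether an amine, a carboxylic acid or a longer chain in place of the aryl group would give a step beyond the scatter.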